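Replacing a dichlorophenyl group with a methylfuran ring

The compounds below may be only part of what the source reports. "The series", "measured", "known", "first", "only" and "open" are said of these compounds alone.

Measured compounds:
compound 1 `N#CC1=C(N)N(c2ccc(S(N)(=O)=O)cc2)C2=C(CCCC2)C1c1ccc(O)cc1` gives 60%
compound 2 `N#CC1=C(N)N(c2ccc(S(N)(=O)=O)cc2)C2=C(CCCC2)C1c1ccc(Cl)cc1Cl` gives 50%
compound 3 `N#CC1=C(N)N(c2ccc(S(N)(=O)=O)cc2)C2=C(CCCC2)C1c1ccc(Cl)c(Cl)c1` gives 50%

All three were tested in a functional assay on Ehrlich cells (Mus musculus) for cytotoxicity, read by trypan blue exclusion, with a stated time of 2 h, tested at 50 ug/mL; on this read-out higher numbers stand for a stronger effect at the one concentration tested and lower numbers for a weaker effect. Compound 3 stands level with compound 2 at the digits shown; together they give the lowest of the three numbers, and compound 1 lies only a little higher. None of these gaps goes beyond the scatter: a number 10 percentage points lower from compound 1 to compound 2 (within the scatter), a number 10 percentage points lower from compound 1 to compound 3 (within the scatter), and no change at the digits printed from compound 2 to compound 3 (within the scatter).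

Compound 4 `Cc1ccc(C2C(C#N)=C(N)N(c3ccc(S(N)(=O)=O)cc3)C3=C2CCCC3)o1` has not yet been measured. It differs from compound 3 in one place: 5-methylfuran-2-yl in place of 3,4-dichlorophenyl on a saturated ring carbon.

All three measured steps bear on this change, since each swaps the aryl group on the same saturated ring carbon, and each stayed within the scatter. Among the measured compounds shown here, no step shows what a five-membered ring with an oxygen does here, but the shared core has so far given much the same number whatever group sat at this position. The expected step is therefore small: no change at the digits printed from compound 3 to compound 4 (within the scatter) is estimated to lie within the scatter.

Compound 4 is expected to give about 50%, in a range from 35% to 65%.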

Compound 4, a percentage reported as activity, at one concentration (the size of the read-out at that concentration, not a potency): 10%
Compound 4: the middle estimate sits 40 percentage points above what was measured; the whole stated range lies above it.
By their numbers in this assay, from the lowest: compound 4; then compounds 2, 3 and 1 (each within the scatter of the next).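

In this assay this saturated ring carbon proves sensitive to its group after all: 5-methylfuran-2-yl brings a number 40 percentage points lower from compound 3 to compound 4 (beyond the scatter) and also a number 40 percentage points lower from compound 2 to compound 4 (beyond the scatter) as well as a number 50 percentage points lower from compound 1 to compound 4 (beyond the scatter). The three groups before it, each a six-membered aromatic ring of carbon only and carrying chlorine or a hydroxy group, stayed within the scatter of one another. Among the compounds shown here, the first step beyond the scatter at this position therefore comes with a five-membered aromatic ring holding an oxygen, so the earlier flat picture holds only among those three groups.

No measurement at hand says why this step is so large. On these data alone, whether the ring oxygen, the methyl group or the five-membered ring itself goes with the lower number stays open; an unsubstituted phenyl, a furan without the methyl, or a thiophene, with sulfur in place of the oxygen, would help separate these.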